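From compound 3 to compound 4: methylsulfonyl on nitrogen

The source may hold more compounds than are shown below. What is called first, only, known or untested is meant among the compounds shown, and "the series" means these compounds.

In a functional assay on A549 cells (Homo sapiens) for antiproliferative activity, read by sulforhodamine B assay, with a stated time of 72 h (on this read-out higher numbers stand for weaker inhibition and lower numbers for stronger inhibition), compound 1 (`COc1ccc(/C=C2\CCC=CC2=O)c(C)c1`) gives 1550 nM and compound 2 (`COc1cc(/C=C2\CN(C(=O)OCc3ccccc3)C=CC2=O)cc(OC)c1OC`) gives 21300 nM. Compound 3 (`COc1cc(/C=C2\CNC=CC2=O)cc(OC)c1OC`) reads > 25000 nM, which is a limit of the assay and not a number. Compound 3 therefore stands at the limit of > 25000 nM in this assay, at which 1 of the 3 values shown sits.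

Compound 4 (`COc1cc(/C=C2\CN(S(C)(=O)=O)C=CC2=O)cc(OC)c1OC`) has methylsulfonyl in place of hydrogen on the amine nitrogen in the ring of compound 3: methylsulfonyl in place of hydrogen on an amine nitrogen in a ring.

Among the compounds with values here, one measured step bears on this nitrogen, the exchange of benzyloxycarbonyl for hydrogen: an at least 1.1-fold higher number from compound 2 to compound 3 (0.06 log units; that floor lies within the scatter). As far as these compounds go, that step is bounded on one side only, so its true size remains open. Compound 1 has no such nitrogen and offers no guidance here. Within the data shown here, the only compound with a substituent on this nitrogen and a measured number is compound 2, at 21300 nM, and that single example gives weak support for a small gain. The expected change in this assay is therefore slight, towards stronger inhibition, and it may not exceed the scatter. The expected step is an at least 1.6-fold lower number from compound 3 to compound 4 (0.22 log units; that floor lies within the scatter). A reading at the limit again would not be surprising. For compound 4 the estimated value is 15000 nM, with an expected range of 5000 nM to 25000 nM.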

Compound 4, half-maximal inhibitory concentration: 18700 nM
Compound 4: middle estimate off by 1.2-fold (0.10 log units), on the low side; the range from low to high includes it.
By their numbers in this assay, from the lowest: compound 1; then compounds 4 and 2 (each within the scatter of the next). At a limit, above all of these: compound 3.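

Benzyloxycarbonyl and methylsulfonyl on the amine nitrogen in the ring read alike in this assay, with a 1.1-fold lower number from compound 2 to compound 4 (0.06 log units; within the scatter) as the step between them, so the change from one substituent to a quite different one, with no ring and only 4 heavy atoms, moves nothing beyond the scatter. Methylsulfonyl in place of hydrogen on the same nitrogen gives an at least 1.3-fold lower number from compound 3 to compound 4 (0.12 log units; that floor lies within the scatter), a floor that by itself does not separate a substituted nitrogen from the unsubstituted one, although it points the same way as the step read from the benzyloxycarbonyl side. As far as these compounds go, the true size of this step stays open because compound 3 stands at a limit of the assay and not at a number: the limit of > 25000 nM in this assay, at which 1 of the 4 values shown sits.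

The compounds shown leave open how a plain methyl, an acetyl or a longer chain ending in an amine or a carboxylic acid on this nitrogen would read in this assay, and whether any such group gives values clearly apart from those of compound 2 and compound 4. With only two measured substituents on this nitrogen, no trend with the kind or size of the group can be drawn.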